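Hydroxycyclohexenyl in place of the aromatic ring

This account rests on a few compounds, and the source may have more. Where it says the series, first, only, none or still open, it means among the compounds named here.

Within the data shown here, compound 3 `C[C@@H](O[C@H]1CN2C(=O)C=C(c3ccc[n+]([O-])c3)CC2[C@@H]1c1ccc(F)cc1)c1cc(C(F)(F)F)cc(C(F)(F)F)c1` gives 2.3 nM in an assay on CHO cells for displacement of a labelled ligand from Substance-P receptor (Homo sapiens), in the presence of a further agent that is not named here (a lower number here means a stronger inhibitor, a higher number a weaker inhibitor), the lowest of the three numbers measured so far. Compound 2 `C[C@@H](O[C@H]1CN2C(=O)C=C(c3cc[nH]c(=O)c3)CC2[C@@H]1c1ccc(F)cc1)c1cc(C(F)(F)F)cc(C(F)(F)F)c1` gives 3.9 nM in this assay, and the step of a 1.7-fold lower number from compound 2 to compound 3 (0.23 log units; within the scatter) separates the two. Compound 1 `C[C@@H](O[C@H]1CN2C(=O)C=C(c3ccc(F)cc3)CC2[C@@H]1c1ccc(F)cc1)c1cc(C(F)(F)F)cc(C(F)(F)F)c1` gives 100 nM, and the steps of a 26-fold lower number from compound 1 to compound 2 (1.41 log units; beyond the scatter) and a 43-fold lower number from compound 1 to compound 3 (1.64 log units; beyond the scatter) are the large ones in this set. Compound 4 `C[C@@H](O[C@H]1CN2C(=O)C=C(C3=CCC(O)CC3)CC2[C@@H]1c1ccc(F)cc1)c1cc(C(F)(F)F)cc(C(F)(F)F)c1` differs from compound 3 by a group of 7 heavy atoms (6 carbon, 1 oxygen; one six-membered non-aromatic ring of carbon only) in place of a group of 7 heavy atoms (5 carbon, 1 nitrogen, 1 oxygen; one six-membered aromatic ring with 1 hetero atom), on a double-bonded ring carbon. The two large steps bear on this only loosely: each swaps one six-membered aromatic ring for another on the same double-bonded ring carbon, and each lowers the number a lot. Among the measured compounds shown here, no measured step replaces the aromatic ring with a non-aromatic one, so the direction is uncertain. Compound 4 is expected to give a higher number than compound 3, since the gain a 43-fold lower number from compound 1 to compound 3 (1.64 log units; beyond the scatter) came with a hetero atom in an aromatic ring that compound 4 lacks. For compound 4 the estimate in this assay is 15 nM, range 3 nM to 70 nM, an expected step of a 6.5-fold higher number from compound 3 to compound 4 (0.81 log units; beyond the scatter).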

Compound 4, half-maximal inhibitory concentration: 13 nM
Compound 4: middle estimate off by 1.2-fold (0.06 log units), on the high side, and the stated range covers the measured number.
By their numbers in this assay, from the lowest: compounds 3 and 2 (each within the scatter of the next); then compound 4; then compound 1.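

In this assay, an aromatic ring is not needed on the double-bonded ring carbon: exchanging 4-fluorophenyl for 4-hydroxycyclohex-1-en-1-yl, a non-aromatic ring of carbon only, gives a 7.7-fold lower number from compound 1 to compound 4 (0.89 log units; beyond the scatter), so a good part of the gain seen with the aromatic rings bearing a hetero atom is kept. That gain is not fully matched, with a 5.7-fold higher number from compound 3 to compound 4 (0.75 log units; beyond the scatter) and a 3.3-fold higher number from compound 2 to compound 4 (0.52 log units; beyond the scatter), so at this position the two aromatic rings with a hetero atom keep an edge over the hydroxylated non-aromatic ring. No measurement here accounts for these differences.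

Open, going by these compounds, is how an unsubstituted cyclohexenyl would compare, which would separate the contribution of the hydroxyl from that of the ring itself. Equally open, on these data alone, is how an amine or a carboxylic acid would read in place of the hydroxyl.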